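Methyl in Place of Iodine on the Thiourea Phenyl Ring

The compounds below may be only part of what the source reports. "The series", "measured", "known", "first", "only" and "open" are said of these compounds alone.

Of the compounds shown here, three sharing one core have been tested in a functional assay on MKN-74 cells (Homo sapiens) for antiproliferative activity, with a stated time of 24 h; on this read-out higher numbers stand for weaker inhibition and lower numbers for stronger inhibition. Compound 1, `NC(=O)c1c(NC(=O)c2ccccc2Cl)sc2c1CCN(Cc1c(Cl)cccc1Cl)C2`, gives 4740 nM. Compound 2, `NC(=O)c1c(NC(=O)c2ccccc2Cl)sc2c1CCN(C(=S)Nc1ccccc1F)C2`, gives 12600 nM, and compound 3, `NC(=O)c1c(NC(=O)c2ccccc2Cl)sc2c1CCN(C(=S)Nc1ccccc1I)C2`, gives 2630 nM. Going by the values given here, compound 3 thus holds the lowest of the three numbers, although its gap to compound 1 is within the usual scatter, so the two cannot be ranked; only the step of a 4.8-fold lower number from compound 2 to compound 3 (0.68 log units; beyond the scatter) stands clearly apart.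

Compound 4, `Cc1ccccc1NC(=S)N1CCc2c(sc(NC(=O)c3ccccc3Cl)c2C(N)=O)C1`, is the next member. It differs from compound 3 by methyl in place of iodo on an aromatic carbon. Among the compounds with values here, the one measured step that bears on this position is the swap of halogens: a 4.8-fold lower number from compound 2 to compound 3 (0.68 log units; beyond the scatter). Methyl is neither fluoro nor iodo, so the expectation rests on an interpolation between those two points, giving a modest rise in this assay, a 1.9-fold higher number from compound 3 to compound 4 (0.28 log units; within the scatter), with considerable uncertainty. Compound 4 is therefore estimated at 5000 nM, expected to fall between 1800 nM and 14000 nM.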

Compound 4, half-maximal inhibitory concentration: 11700 nM
Beside the measured number, compound 4's estimate is 2.3-fold (0.37 log units) below it, and the stated range covers the measured number.
By their numbers in this assay, from the lowest: compounds 3 and 1 (each within the scatter of the next); then compounds 4 and 2 (each within the scatter of the next).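

In this assay the step of a 4.4-fold higher number from compound 3 to compound 4 (0.65 log units; beyond the scatter) is about as large as the step of a 4.8-fold lower number from compound 2 to compound 3 (0.68 log units; beyond the scatter) in the opposite direction, while a 1.1-fold lower number from compound 2 to compound 4 (0.03 log units; within the scatter) leaves methyl and fluoro impossible to tell apart. Among the three groups shown on this aromatic carbon, only iodo sets its compound apart, even though methyl replaces it one heavy atom for one. The step of a 2.5-fold higher number from compound 1 to compound 4 (0.39 log units; beyond the scatter) contrasts with compound 3, which could not be separated from compound 1, so in these compounds the group on this carbon decides whether a thiourea compound matches compound 1.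

Nothing available here explains why iodo behaves differently from methyl and fluoro. Going by these compounds, whether chloro, bromo or methoxy on this carbon would group with iodo or with methyl and fluoro remains open.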